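Hydroxyethoxy replacing ethylcarbamoyl on the piperidine of compound 2

A few compounds are considered here, and "the series" means these few. Any claim that something is new, unique, unknown or untested is made for them only; others in the source may bear on it.

Compound 2 `CCCCCOC(=O)N1CCN(C(=O)[C@H](CCC(=O)O)NC(=O)c2cc(N3CCC(C(=O)NCC)CC3)nc(-c3ccccc3)n2)CC1` is one of two measured compounds in an in vivo ADME assay on the whole organism (strain Sprague-Dawley) for pharmacokinetics, with Rattus norvegicus as the target; a higher number here means faster removal of the compound, a lower number slower removal; in this assay compound 2 gives 8 mL/min/kg, and the other measured compound, compound 1 `CCCCCOC(=O)N1CCN(C(=O)[C@H](CCC(=O)O)NC(=O)c2cc(N3CCC(C(=O)N(CC)CC)CC3)nc(-c3ccccc3)n2)CC1`, gives 6 mL/min/kg. For the measured compounds named here, the only measured step, a 1.3-fold higher number from compound 1 to compound 2 (0.12 log units; within the scatter), concerns hydrogen in place of ethyl on an amide-type nitrogen and lies within the scatter, so the two numbers are not distinguishable. Compound 3 `CCCCCOC(=O)N1CCN(C(=O)[C@H](CCC(=O)O)NC(=O)c2cc(N3CCC(OCCO)CC3)nc(-c3ccccc3)n2)CC1` differs from compound 2 by 2-hydroxyethoxy in place of ethylcarbamoyl on a saturated ring carbon. Going by the values given here, no measured step touches this kind of exchange, and the single step that exists does not bear on it. The shared core and the rest of the molecule are unchanged, so the expectation rests on compound 2 alone, with a wide range. Compound 3 is therefore estimated at 9 mL/min/kg, between 4 mL/min/kg and 22 mL/min/kg, an expected step of a 1.1-fold higher number from compound 2 to compound 3 (0.05 log units; within the scatter) that is not beyond the scatter.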

Compound 3, clearance: 18 mL/min/kg
Estimate against measurement, compound 3: 2.0-fold (0.30 log units) below; low and high end bracket the measured number.
By their numbers in this assay, from the lowest: compounds 1 and 2 (each within the scatter of the next); then compound 3.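

In this assay, for the compounds shown here, the change from 4-(ethylcarbamoyl)piperidin-1-yl to 4-(2-hydroxyethoxy)piperidin-1-yl gives a 2.3-fold higher number from compound 2 to compound 3 (0.35 log units; beyond the scatter) and is the first step here to lie beyond the scatter. Against the diethylcarbamoyl group, the exchange at the same ring carbon gives a 3.0-fold higher number from compound 1 to compound 3 (0.48 log units; beyond the scatter) and shows that replacing the carbamoyl group altogether moves the number, where changing the substitution on its nitrogen did not. No measurement available here accounts for this rise.

The compounds shown do not separate the ether oxygen from the terminal hydroxyl of the 2-hydroxyethoxy chain, and they do not tell how a methoxy group, an amine or a longer chain ending in hydroxyl would behave on this ring carbon. They also leave open whether the step holds when the rest of the molecule differs.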